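Moving the methyl on the sulfonyl aryl

This account rests on a few compounds, and the source may have more. Where it says the series, first, only, none or still open, it means among the compounds named here.

Compound 3 `Cc1cccc(S(=O)(=O)N2CC(c3nc(-c4cccc(Cl)c4)no3)C2)c1` carries a 3-methylphenyl on its sulfonyl sulfur and in an assay on HEK293 cells for negative allosteric modulation of metabotropic glutamate receptor 5 (Homo sapiens), read by FLIPR (on this read-out higher numbers stand for weaker inhibition and lower numbers for stronger inhibition), gives 390 nM. Among the two numbers measured this is the lowest, and the nearest is compound 2 `Cc1cccc(-c2noc(C3CN(S(=O)(=O)c4cccc(C)c4)C3)n2)c1`, which in this assay gives 650 nM. The step of a 1.7-fold lower number from compound 2 to compound 3 (0.22 log units; within the scatter) lies within the scatter. Compound 1 `CC1CCCCC1C(=O)N1CC(c2nc(-c3cccc(F)c3)no2)C1` has an amide in place of the sulfonamide; in this assay compound 1 reaches only a limit of the assay, > 10000 nM, and the limit of > 10000 nM in this assay, at which 1 of the 3 values shown sits, marks that limit.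

Compound 4 `Cc1ccc(S(=O)(=O)N2CC(c3nc(-c4cccc(Cl)c4)no3)C2)cc1` is not yet measured. It differs from compound 3 by 4-methylphenyl in place of 3-methylphenyl on a sulfonyl sulfur. Within the data shown here, none of the measured steps touches the aryl on the sulfonyl sulfur; the one measured step concerns the other aryl and is within the scatter, so it gives no direction for this change. Compound 4 is therefore expected to sit near compound 3. The step of a 1.3-fold higher number from compound 3 to compound 4 (0.11 log units; within the scatter) is expected to stay within the scatter. The estimate for compound 4 in this assay is 500 nM, within a range from 200 nM to 1500 nM.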

Compound 4, half-maximal inhibitory concentration: 920 nM
Beside the measured number, compound 4's estimate is 1.8-fold (0.26 log units) below it; the measured number falls inside the stated range.
By their numbers in this assay, from the lowest: compounds 3, 2 and 4 (each within the scatter of the next, the first and the last beyond it). At a limit, above all of these: compound 1.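

In this assay, where the methyl sits on the aryl carried by the sulfonyl sulfur makes a measurable difference: the move gives a 2.4-fold higher number from compound 3 to compound 4 (0.37 log units; beyond the scatter) and changes neither the atoms present nor the counts of donors and acceptors. This is the only step shown that touches this aryl and, though modest, the only one shown that lies beyond the scatter, so this position responds to a change that the earlier compounds left untested. Nothing measured on these compounds accounts for the step.

Going by these compounds, whether a methoxy, an amine or a carboxylic acid on this aryl would give a higher or a lower number stays open. Also open, on these data alone, is whether the step would keep its size with a group other than chloro on the other aryl.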